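Glycine extension of the ester in compound 2

The source may report more compounds than this note shows. Statements on the series, on what has been measured and on what is new or still open speak of the compounds shown alone.

Compound 2 `CCCC(=O)OCSc1ccccc1C(=O)NCC(=O)OC` stands highest of the two numbers in an ADME assay on CEM-SS cells (Homo sapiens) for cytotoxicity, read by XTT assay, with a stated time of 6 days (a lower number here means that less compound is tolerated, a higher number that more compound is tolerated), giving 27.3 uM; compound 1 `CCCC(=O)OCSc1ccccc1C(=O)NCCCCCCNC(C)=O` gives 8 uM, and the step of a 3.4-fold higher number from compound 1 to compound 2 (0.53 log units; beyond the scatter) lies beyond the scatter. Compound 3 `CCCC(=O)OCSc1ccccc1C(=O)NCC(=O)NCC(=O)OC` is unmeasured and differs from compound 2 by ((methoxycarbonyl)methyl)amino in place of methoxy on a carbonyl carbon. Among the compounds with values here, no measured step covers this change: the only known step exchanged the whole chain on the amide-type nitrogen and is not a direct precedent. The extension is expected to move the number only a little, a 1.3-fold higher number from compound 2 to compound 3 (0.11 log units; within the scatter), with the direction uncertain. Compound 3 is estimated at 35 uM, in the range 15 uM to 80 uM.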

Compound 3, half-maximal toxic concentration: > 100 uM
Compound 3: no number, only a limit (the forecaster's own chance of this, stated with the estimate: 10%); middle value at least 2.8-fold (0.45 log units) away from the limit.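

In this assay compound 3 gives > 100 uM, a limit of the assay and not a number. On this carbonyl carbon, ((methoxycarbonyl)methyl)amino in place of methoxy gives an at least 3.6-fold higher number from compound 2 to compound 3 (0.56 log units; beyond the scatter), and the exchange of the whole chain on the amide-type nitrogen gives an at least 12-fold higher number from compound 1 to compound 3 (1.09 log units; beyond the scatter). Both steps are minimum sizes only: the limit of > 100 uM in this assay, at which 1 of the 3 values shown sits.

Which part of the entering group carries the step, the amide hydrogen or the methoxycarbonyl, remains open. Also open, on these data alone, is how a carboxylic acid in place of that methoxycarbonyl, or a longer chain of glycine units, would read.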